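A few compounds are considered here, and "the series" means these few. Any claim that something is new, unique, unknown or untested is made for them only; others in the source may bear on it.

In a functional assay on MDA-MB-231 cells (Homo sapiens) for antiproliferative activity, read by MTT assay, with a stated time of 48 h (a higher number here means a weaker inhibitor, a lower number a stronger inhibitor), compound 1 (`C=CS(=O)(=O)N1CCN(c2ncnc3sc(-c4ccccc4)cc23)CC1`) gives 54200 nM while compound 2 (`C=CS(=O)(=O)N1CCN(c2ccn3ncc(-c4ccccc4)c3n2)CC1`) gives 38300 nM and compound 3 (`C=CS(=O)(=O)N1CCN(c2ncnc3sc(-c4ccc(OC)cc4)cc23)CC1`) gives 29900 nM as its value, which places compound 3 within the scatter of both others. Compound 4 (`C=CS(=O)(=O)N1CCN(c2ncnc3sc(-c4ccc(N5CCN(C)CC5)cc4)cc23)CC1`) carries 4-methylpiperazin-1-yl in place of methoxy on an aromatic carbon, para to a large group (4-methylpiperazin-1-yl in place of methoxy on an aromatic carbon). For the measured compounds named here, the one measured step at that place (a 1.8-fold lower number from compound 1 to compound 3 (0.26 log units; within the scatter)) put methoxy in place of hydrogen and stayed within the scatter, while compound 2 has a different core and offers no step. Going by the values given here, with only that small step as a guide, a modest move toward a lower number, not clearly beyond the scatter, is expected in this assay (a 1.9-fold lower number from compound 3 to compound 4 (0.27 log units; within the scatter)). For compound 4 the estimated value is 16000 nM (expected range 5000 nM to 45000 nM).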

Compound 4, half-maximal inhibitory concentration: 7550 nM
Compound 4: middle estimate off by 2.1-fold (0.33 log units), on the high side; the range from low to high includes it.
By their numbers in this assay, from the lowest: compound 4; then compounds 3, 2 and 1 (each within the scatter of the next).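

At this aromatic carbon, para to a large group, 4-methylpiperazin-1-yl moves the number in this assay beyond the scatter, with a 4.0-fold lower number from compound 3 to compound 4 (0.60 log units; beyond the scatter) and a 7.2-fold lower number from compound 1 to compound 4 (0.86 log units; beyond the scatter) in the same direction. Methoxy in place of hydrogen at the same carbon had stayed within the scatter (a 1.8-fold lower number from compound 1 to compound 3 (0.26 log units; within the scatter)), so this position can respond to substitution. Nothing available explains the size of this step.

From the compounds shown here alone, it remains open whether a smaller amine such as dimethylamino, or morpholin-4-yl, at this carbon would give a similar step. Going by these compounds, whether 4-methylpiperazin-1-yl has the same effect on the core of compound 2 is also open.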